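Replacing the benzyloxy arm of compound 1: amide-linked thiophene

This account rests on a few compounds, and the source may have more. Where it says the series, first, only, none or still open, it means among the compounds named here.

Compound 1 `Cc1nn(-c2ncnc3nc[nH]c23)c2c1C(OCc1ccccc1F)CC(=O)N2` gives 78 nM in a functional assay on HEK293 cells for agonist activity at G-protein coupled receptor 39 (Homo sapiens), read by scintillation proximity assay and inositol phosphate accumulation, with a stated time of 75 min (a lower number here means that less compound is needed, a higher number that more compound is needed for the effect), the lowest of the three numbers measured. Compound 2 `Cc1nn(-c2ncnc3nc[nH]c23)c2c1C(C(=O)NCc1ccccc1)CC(=O)N2` gives 2930 nM and compound 3 `Cc1nn(-c2ncnc3nc[nH]c23)c2c1C(c1ccc(OC(C)C)cc1)CC(=O)N2` gives 2700 nM; the two differ only within the scatter, a 1.1-fold lower number from compound 2 to compound 3 (0.04 log units; within the scatter). Compound 4 `Cc1nn(-c2ncnc3nc[nH]c23)c2c1C(NC(=O)Cc1cccs1)CC(=O)N2` carries (((thiophen-2-yl)methyl)carbonyl)amino in place of (2-fluorobenzyl)oxy on a saturated ring carbon. Both measured departures from that group on the same saturated ring carbon cost heavily: a 38-fold higher number from compound 1 to compound 2 (1.57 log units; beyond the scatter) and a 35-fold higher number from compound 1 to compound 3 (1.54 log units; beyond the scatter). Among the compounds with values here, the closest precedent is compound 2, where an amide replaces the ether as it does in compound 4. A large rise in the number, beyond the scatter, is therefore expected, a 32-fold higher number from compound 1 to compound 4 (1.51 log units; beyond the scatter). The expected value for compound 4 is 2500 nM, with a range from 600 nM to 10000 nM.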

Compound 4, half-maximal effective concentration: 244 nM
For compound 4 the middle estimate is 10-fold (1.01 log units) above the measured one; measured number below the stated range.
By their numbers in this assay, from the lowest: compound 1; then compound 4; then compounds 3 and 2 (each within the scatter of the next).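

An amide-containing arm on this saturated ring carbon need not cost heavily, since the step here is only a 3.1-fold higher number from compound 1 to compound 4 (0.50 log units; beyond the scatter) and compound 1 keeps the lowest number. Compound 2 and compound 3 had not shown this, and the new group stands well clear of both, with a 12-fold lower number from compound 2 to compound 4 (1.08 log units; beyond the scatter) and an 11-fold lower number from compound 3 to compound 4 (1.04 log units; beyond the scatter) on moving to it. No evidence at hand accounts for these differences.

Compound 2 and compound 4 differ in both amide direction and aromatic ring, so the two changes remain unseparated. Open, going by these compounds, is whether a phenyl ring on the compound 4 amide, a longer chain before the thiophene, or a simple amine on this carbon would match compound 1.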